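Ester to Anilide: Expected Shift at the Carbonyl Carbon

The source may report more compounds than this note shows. Statements on the series, on what has been measured and on what is new or still open speak of the compounds shown alone.

Measured compounds:
compound 1 `CCn1c(C(=O)NCCN)ccc1C(CC)(CC)c1ccc(OCCC(O)(CC)CC)c(C)c1`, 156 nM
compound 2 `C#CC(C)OC(=O)c1ccc(C(CC)(CC)c2ccc(OCCC(O)(CC)CC)c(C)c2)n1CC`, 2650 nM
compound 3 `C#CCCOC(=O)c1ccc(C(CC)(CC)c2ccc(OCCC(O)(CC)CC)c(C)c2)n1CC`, 6030 nM

In an assay on cells for agonist activity at vitamin D3 receptor (Homo sapiens), with a stated time of 96 h (a lower number here means that less compound is needed, a higher number that more compound is needed for the effect), compound 1 gives 156 nM, compound 2 gives 2650 nM and compound 3 gives 6030 nM. Compound 3 stands highest of the three: compound 2 is nearest, and compound 1 is furthest, both steps lying beyond the scatter.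

The step under consideration leads to compound 4 `CCn1c(C(=O)Nc2ccc(OC(F)(F)F)cc2)ccc1C(CC)(CC)c1ccc(OCCC(O)(CC)CC)c(C)c1`. The change is (4-(trifluoromethoxy)phenyl)amino in place of (but-3-yn-1-yl)oxy on a carbonyl carbon.

Among the measured compounds shown here, two measured steps bear on it, since both replace an amide-type group with an ester on the same carbonyl carbon: a 17-fold higher number from compound 1 to compound 2 (1.23 log units; beyond the scatter) and a 39-fold higher number from compound 1 to compound 3 (1.59 log units; beyond the scatter). For the measured compounds named here, the reverse direction, from an ester on that carbonyl carbon back to an amino group, is what compound 4 represents, though the entering group differs from the one in compound 1. The step of a 2.3-fold higher number from compound 2 to compound 3 (0.36 log units; beyond the scatter) shows how much the two esters differ from each other in this assay.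

On this basis a clearly lower number is expected for compound 4 than for compound 3, the step estimated as a 15-fold lower number from compound 3 to compound 4 (1.18 log units; beyond the scatter). Compound 4 is therefore estimated at 400 nM, with a range from 80 nM to 2000 nM.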

Compound 4, half-maximal effective concentration: > 10000 nM
Compound 4 gave a limit, no number (the forecaster's own chance of this, stated with the estimate: 5%); middle value at least 25-fold (1.39 log units) from the limit.
By their numbers in this assay, from the lowest: compound 1; then compound 2; then compound 3. At a limit, above all of these: compound 4.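

In this assay compound 4 gives > 10000 nM, which is a limit of the assay and not a number. The earlier compounds held only one amide-type group on this carbonyl carbon, and here a second one does not share its low number, with an at least 64-fold higher number from compound 1 to compound 4 (1.80 log units; beyond the scatter): among the compounds shown, the low number therefore goes with 2-aminoethyl on the amide-type nitrogen, not with that nitrogen alone. Nor does replacing an ester with this amide-type group bring the number down, as an at least 3.7-fold higher number from compound 2 to compound 4 (0.57 log units; beyond the scatter), while an at least 1.6-fold higher number from compound 3 to compound 4 (0.21 log units; that floor lies within the scatter), so against compound 3 the floor alone establishes no difference.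

From the compounds shown here alone, how far the true value of compound 4 lies past the limit remains open: the limit of > 10000 nM in this assay, at which 1 of the 4 values shown sits. Also open, going by these compounds, is which part of the entering group matters, since a plain phenyl on that nitrogen, a short alkyl chain, or a longer amine such as 3-aminopropyl would separate the aromatic ring and the trifluoromethoxy group from the loss of the terminal amine.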